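The source may report more compounds than this note shows. Statements on the series, on what has been measured and on what is new or still open speak of the compounds shown alone.

Compound 1 `C=CCOC(=O)c1ccsc1NC(=O)[C@@H]1CCCN1` carries an allyl ester on the shared core, and in a toxicity assay on HUVEC cells (Homo sapiens) for inhibition (on this read-out lower numbers stand for stronger inhibition of growth and higher numbers for weaker inhibition of growth), compound 1 gives 149 ug/mL. Compound 2 `O=C1CC[C@@H](COC(=O)c2ccsc2NC(=O)[C@@H]2CCCN2)N1` gives 88.6 ug/mL in this assay, and the change a 1.7-fold lower number from compound 1 to compound 2 (0.23 log units; within the scatter) lies within the scatter, so the two numbers cannot be ordered. Compound 3 `O=C(OCC(F)(F)F)c1ccsc1NC(=O)[C@@H]1CCCN1` reaches only a limit in this assay, > 250 ug/mL, as noted in the limit of > 250 ug/mL in this assay, at which 1 of the 3 values shown sits. Compound 4 `O=C(OCc1ccccc1)c1ccsc1NC(=O)[C@@H]1CCCN1` differs from compound 1 by phenyl in place of vinyl on a saturated chain carbon bound to an oxygen next to a carbonyl group. Among the compounds with values here, no measured step introduces phenyl; the steps at this place, an at least 1.6-fold higher number from compound 1 to compound 3 (0.22 log units; that floor lies within the scatter) and an at least 2.8-fold higher number from compound 2 to compound 3 (0.45 log units; beyond the scatter), leave the direction open. Compound 4 is therefore expected to give 130 ug/mL, between 55 ug/mL and 250 ug/mL. The expected step is a 1.1-fold lower number from compound 1 to compound 4 (0.06 log units; within the scatter), none beyond the scatter.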

Compound 4, concentration for 50% growth inhibition: > 250 ug/mL
Compound 4 was reported as a limit; the forecaster's own chance of this, stated with the estimate: 20%; middle value at least 1.9-fold (0.28 log units) from the limit.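

At this place, phenyl in place of vinyl gives an at least 1.6-fold higher number from compound 1 to compound 4 (0.22 log units; that floor lies within the scatter), so an aromatic ring here brings no stronger inhibition of growth, and it gives an at least 2.8-fold higher number from compound 2 to compound 4 (0.45 log units; beyond the scatter), which sets compound 2 apart from a second group. Compound 4 stands at a limit in this assay, not at a number: the limit of > 250 ug/mL in this assay, at which 2 of the 4 values shown sit. The step between compound 3 and compound 4 cannot be read, as both values are limits. On these data alone, how far beyond the limit these two compounds lie stays open. So does what an amine or a carboxylic acid at this place would give.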